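The source may report more compounds than this note shows. Statements on the series, on what has been measured and on what is new or still open speak of the compounds shown alone.

Measured compounds:
- compound 1, `O=C(O)c1ccc(NCc2cccc(Oc3ccccc3)c2)cc1`: < 10000 nM in a functional assay on CHO cells for agonist activity at Free fatty acid receptor 1 (Homo sapiens); on this read-out higher numbers stand for an effect only at larger amounts of compound and lower numbers for an effect already at smaller amounts.
- compound 2, `NC(=O)CCc1ccc(NCc2cccc(Oc3ccccc3)c2)cc1`: 51.3 nM.
- compound 3, `O=C(CCc1ccc(NCc2cccc(Oc3ccccc3)c2)cc1)N1CCCC1`: 115 nM.

The value of compound 1 is a limit of this assay, not a number (the limit of < 10000 nM in this assay, at which 1 of the 3 values shown sits). Compound 3 holds the highest of the two readable numbers; compound 2 is nearest, set apart by a 2.2-fold higher number from compound 2 to compound 3 (0.35 log units; beyond the scatter). The steps a step that the limit leaves unreadable from compound 1 to compound 2 and a step that the limit leaves unreadable from compound 1 to compound 3 cannot be sized.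

Compound 4, `O=C(NO)[C@H]1C[C@@H]1c1ccc(NCc2cccc(Oc3ccccc3)c2)cc1`, differs from compound 3 by 2-(hydroxycarbamoyl)cyclopropyl in place of 2-((pyrrolidin-1-yl)carbonyl)ethyl on an aromatic carbon. Among the compounds with values here, only the measured step from compound 2 to compound 3 bears on this, and it was modest; no measured pair covers the hydroxycarbamoyl or the cyclopropyl. Compound 4 is therefore expected near the two readable numbers, with the step of a 1.4-fold lower number from compound 3 to compound 4 (0.16 log units; within the scatter) estimated as small and uncertain in direction. Compound 4 is expected at 80 nM, between 20 nM and 400 nM.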

Compound 4, half-maximal effective concentration: 14.8 nM
The estimate for compound 4 lay 5.4-fold (0.73 log units) above the measured number, outside the stated range (below it).
By their numbers in this assay, from the lowest: compound 4; then compound 2; then compound 3.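

In this assay, 2-(hydroxycarbamoyl)cyclopropyl on this aromatic carbon, para to a large group, gives a 7.8-fold lower number from compound 3 to compound 4 (0.89 log units; beyond the scatter) and a 3.5-fold lower number from compound 2 to compound 4 (0.54 log units; beyond the scatter), so both earlier amide side chains are surpassed beyond the scatter. Compound 1 holds a limit, not a number, so its steps cannot be read: the limit of < 10000 nM in this assay, at which 1 of the 4 values shown sits. Nothing measured here accounts for these steps.

The hydroxycarbamoyl and the cyclopropyl enter together, so their shares remain unseparated. As far as these compounds go, a 2-(hydroxycarbamoyl)ethyl chain or a 2-carbamoylcyclopropyl group would divide them, and the opposite cyclopropyl stereoisomer remains open.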